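Methyl in Place of Methoxy: Expecting the Value of Compound 4

The compounds below may be only part of what the source reports. "The series", "measured", "known", "first", "only" and "open" are said of these compounds alone.

Compound 1 `COc1ccc(NC(=S)OCCNC(=O)C(C)(C)Oc2ccc(Cl)cc2)cc1`: 15200 nM
Compound 2 `COc1ccc(NC(=S)OCCNC(=O)c2cccnc2)cc1`: 14700 nM
Compound 3 `Cc1ccc(NC(=S)OCCNC(=O)C(C)(C)Oc2ccc(Cl)cc2)cc1`: 15800 nM

Of the compounds shown here, three have been measured in an ADME assay for pharmacokinetics, in phosphate buffer, with a stated time of 0.25 h, tested at 60 uM, at a dose of 60 microM; on this read-out lower numbers stand for lower exposure and higher numbers for higher exposure at the dose given. Compound 1 gives 15200 nM in this assay, compound 2 gives 14700 nM, and compound 3 gives 15800 nM. All three numbers lie close together, so none can be called higher or lower than another.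

Compound 1 and compound 3 differ in one place, with methyl in place of methoxy on an aromatic carbon. The step is a 1.0-fold higher number from compound 1 to compound 3 (0.02 log units; within the scatter). Compound 1 and compound 2 share the same change-bearing ring but differ elsewhere; how the two cores differ is not broken down here.

Compound 4 `Cc1ccc(NC(=S)OCCNC(=O)c2cccnc2)cc1` has not been measured. It carries the same change relative to compound 2, with methyl in place of methoxy on an aromatic carbon, at the same kind of place. Since that change moved the number only as a 1.0-fold higher number from compound 1 to compound 3 (0.02 log units; within the scatter), a similarly small step is expected from compound 2, namely a 1.0-fold higher number from compound 2 to compound 4 (0.02 log units; within the scatter). Compound 4 is therefore estimated at 15300 nM, with a likely span from 10500 nM to 22000 nM.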

Compound 4, maximal plasma concentration: 18300 nM
For compound 4 the middle estimate is 1.2-fold (0.08 log units) below the measured one, and the stated range covers the measured number.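

In this assay, putting methyl in place of methoxy gives a 1.2-fold higher number from compound 2 to compound 4 (0.10 log units; within the scatter), so on this second core the change again leaves the number within the usual scatter. Set beside the earlier step, the two cores give the same picture: the same change on two cores in this assay, a 1.0-fold higher number (0.02 log units; within the scatter) from compound 1 to compound 3 and a 1.2-fold higher number (0.10 log units; within the scatter) from compound 2 to compound 4, 1.2-fold (0.08 log units) apart, within the scatter of two such steps

This shows that, for these two cores, the swap of methoxy for methyl can be carried across with little effect on the read-out, but it does not show that the same would hold on any other core, and two steps this small give no test of whether a large step would carry across in the same way.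

The compounds shown leave open what other groups on the same aromatic carbon, such as an amine, a carboxylic acid or a trifluoromethyl group, would do to the number. They also leave open whether any group at this place can give a step beyond the scatter, and whether such a step would then be the same on both cores.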